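The source may hold more compounds than are shown below. What is called first, only, known or untested is meant among the compounds shown, and "the series" means these compounds.

Measured so far in a functional assay on A-431 cells (Homo sapiens) for cytotoxicity, read by MTT assay, with a stated time of 48 h; a higher number here means a weaker inhibitor, a lower number a stronger inhibitor:
compound 1 `CCCCCCCCCCCCCCNC(=O)[C@@H](NC(=O)c1ccccc1)[C@@H](C)O`: 118000 nM
compound 2 `CCCCCCCCCCCCCCCCCCNC(=O)[C@@H](NC(=O)c1ccccc1)[C@@H](C)O`: 113000 nM

Two compounds of the series have numbers. In this assay compound 1 gives 118000 nM and compound 2 gives 113000 nM. For the measured compounds named here, the single step between them, a 1.0-fold lower number from compound 1 to compound 2 (0.02 log units; within the scatter), is within the scatter, so the two values are read as the same number; compound 2 has the lower of the two, but its distance to compound 1 is within the scatter and no order is claimed.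

Compound 3 `CCCCCCCCCCCCCCCCCCNC(=O)[C@@H](NC(=O)/C=C/c1ccccc1)[C@@H](C)O` differs from compound 2 at the carbonyl carbon: 2-phenylethenyl in place of phenyl on a carbonyl carbon. Going by the values given here, the one measured step concerns a saturated chain carbon far from the amide-type nitrogen and does not bear on a change at the carbonyl carbon; nothing measured here speaks to this change. Among the compounds with values here, with no step to lean on, the expectation is a number close to that of compound 2, and the step is estimated as a 1.1-fold lower number from compound 2 to compound 3 (0.05 log units; within the scatter), not beyond the scatter. Compound 3 is expected to give 100000 nM in this assay, with a range from 40000 nM to 250000 nM.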

Compound 3, half-maximal inhibitory concentration: 177000 nM
Estimate against measurement, compound 3: 1.8-fold (0.25 log units) below, and the stated range covers the measured number.
By their numbers in this assay, from the lowest: compounds 2, 1 and 3 (each within the scatter of the next).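

In this assay, for the compounds shown here, the change on the carbonyl carbon, 2-phenylethenyl in place of phenyl, gives a 1.6-fold higher number from compound 2 to compound 3 (0.19 log units; within the scatter); this is the first measured step at this position, and until now the only step lay on the saturated chain. The benzamido and ((2-phenylethenyl)carbonyl)amino forms therefore read as the same number on the chain shared by compound 2 and compound 3, and going from 6 to 8 heavy atoms, with one double bond outside aromatic rings, stays within the scatter. Nothing at hand bears on why this change leaves the number within the scatter.

The compounds shown cover only two groups on this carbonyl carbon, both carrying an unsubstituted aromatic ring of carbon only, so it remains open whether 2-phenylethyl, or an amine or a carboxylic acid on that ring, would give a step beyond the scatter. Also open, going by these compounds, is whether a much shorter chain on the amide-type nitrogen, or a free hydroxyl replaced by a methoxy group, would give such a step from compound 2.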